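A few compounds are considered here, and "the series" means these few. Any claim that something is new, unique, unknown or untested is made for them only; others in the source may bear on it.

Of the compounds shown here, three built on one shared core have been measured in a functional assay on LNCaP cells (Homo sapiens) for antiproliferative activity; a lower number here means a stronger inhibitor, a higher number a weaker inhibitor. Compound 1 `Cn1ncc(Cl)c1-c1cc(C(=O)N[C@@H]2CN[C@H](CCn3cncn3)C[C@H]2c2ccc(Cl)c(Cl)c2)oc1Cl` gives 60 nM in this assay, compound 2 `C=CC[C@@H]1C[C@@H](c2ccc(Cl)c(Cl)c2)[C@H](NC(=O)c2cc(-c3c(Cl)cnn3C)c(Cl)o2)CN1` gives 160 nM, and compound 3 `Cn1ncc(Cl)c1-c1cc(C(=O)N[C@@H]2CN[C@H](CC(=O)NC3CCC3)C[C@H]2c2ccc(Cl)c(Cl)c2)oc1Cl` gives 80 nM. Among these three numbers compound 3 holds the second highest place, with compound 1 nearest to it and compound 2 furthest, both gaps lying within the scatter. Among the compounds with values here, the steps so far are a 1.3-fold higher number from compound 1 to compound 3 (0.12 log units; within the scatter) and a 2.0-fold lower number from compound 2 to compound 3 (0.30 log units; within the scatter), both within the scatter, and a 2.7-fold higher number from compound 1 to compound 2 (0.43 log units; beyond the scatter), the only step beyond it. Compound 4 `CNC(=O)C[C@@H]1C[C@@H](c2ccc(Cl)c(Cl)c2)[C@H](NC(=O)c2cc(-c3c(Cl)cnn3C)c(Cl)o2)CN1` is not yet measured. It differs from compound 3 in one place: methyl in place of cyclobutyl on an amide-type nitrogen. Within the data shown here, none of the measured steps alters the group on this amide nitrogen; they exchange the whole side chain on the saturated ring carbon, and even those exchanges stayed mostly within the scatter. A smaller change at the end of that same chain is therefore expected to give no step beyond the scatter, no change at the digits printed from compound 3 to compound 4 (within the scatter). For compound 4 the estimate is 80 nM, with a range from 40 nM to 160 nM.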

Compound 4, half-maximal inhibitory concentration: 40 nM
Estimate against measurement, compound 4: 2.0-fold (0.30 log units) above, and the stated range covers the measured number.
By their numbers in this assay, from the lowest: compounds 4, 1, 3 and 2 (each within the scatter of the next, the first and the last beyond it).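

In this assay, the group on the amide-type nitrogen goes from cyclobutyl to methyl, and with it the four-membered ring, without a step beyond the scatter (a 2.0-fold lower number from compound 3 to compound 4 (0.30 log units; within the scatter)). The methylcarbamoyl side chain of compound 4 also stays within the scatter of the (1H-1,2,4-triazol-1-yl)methyl side chain (a 1.5-fold lower number from compound 1 to compound 4 (0.18 log units; within the scatter)). Against vinyl, however, methylcarbamoyl gives a modest step beyond the scatter (a 4.0-fold lower number from compound 2 to compound 4 (0.60 log units; beyond the scatter)), whereas cyclobutylcarbamoyl did not, so the choice of group on this nitrogen decides whether the gap to compound 2 clears the scatter, though only just.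

No measurement available here bears on why these steps have the sizes they do. Going by these compounds, whether a bare carbamoyl, a dimethylamide or a carboxylic acid at the end of this chain would hold the same level remains open.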